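This account rests on a few compounds, and the source may have more. Where it says the series, first, only, none or still open, it means among the compounds named here.

In a functional assay on HeLa cells (Homo sapiens) for antiproliferative activity, with a stated time of 48 h (a higher number here means a weaker inhibitor, a lower number a stronger inhibitor), three compounds have been measured:
compound 1 `C=C(Br)C(=O)Nc1ccc(C(=O)/C=C/c2cccc(OC)c2)cc1`: 500 nM
compound 2 `C=C(Br)C(=O)Nc1ccc(C(=O)/C=C/c2ccccc2OC)cc1`: 1300 nM
compound 3 `C=C(Br)C(=O)Nc1ccc(C(=O)/C=C/c2ccc(OC)c(OC)c2)cc1`: 770 nM

All three share the same core and differ only at the aryl end of the chain. Compound 2 differs from compound 1 by 2-methoxyphenyl in place of 3-methoxyphenyl on a double-bonded chain carbon bound to a double-bonded chain carbon, and in this assay that gives a 2.6-fold higher number from compound 1 to compound 2 (0.41 log units; beyond the scatter). Compound 3 differs from compound 1 by methoxy in place of hydrogen on an aromatic carbon, and that gives a 1.5-fold higher number from compound 1 to compound 3 (0.19 log units; within the scatter). Compound 2 is separated beyond the scatter only from compound 1; its gap to compound 3 lies within the scatter.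

Compound 4 `C=C(Br)C(=O)Nc1ccc(C(=O)/C=C/c2ccc(OC)cc2OC)cc1` has not been measured. It differs from compound 2 by methoxy in place of hydrogen on an aromatic carbon. Among the measured compounds shown here, this is the same kind of change as the one from compound 1 to compound 3, but not the same: in compound 3 the entering methoxy is ortho to a methoxy group, in compound 4 it is meta to a methoxy group, and in both it is para to a large group. With one earlier case to rest on, compound 4 is expected to show a step of a 1.4-fold higher number from compound 2 to compound 4 (0.14 log units; within the scatter), close to the earlier 1.5-fold higher number from compound 1 to compound 3 (0.19 log units; within the scatter). Compound 4 is therefore estimated at 1800 nM, between 800 nM and 4000 nM.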

Compound 4, half-maximal inhibitory concentration: 1100 nM
Estimate against measurement, compound 4: 1.6-fold (0.21 log units) above; measured number inside the range.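

In this assay, methoxy in place of hydrogen on the core of compound 2, where it enters meta to a methoxy group and para to a large group, gives a 1.2-fold lower number from compound 2 to compound 4 (0.07 log units; within the scatter). Set beside the same change on the core of compound 1, the new step does not differ from the earlier one by more than the scatter of two such steps, so in these two cases the change leaves the number within the scatter on either core: the same change on two cores in this assay, a 1.5-fold higher number (0.19 log units; within the scatter) from compound 1 to compound 3 and a 1.2-fold lower number (0.07 log units; within the scatter) from compound 2 to compound 4, 1.8-fold (0.26 log units) apart, within the scatter of two such steps This does not show that the change carries a fixed size from core to core, since it rests on only two pairs, neither step stands clear of the scatter, and the methoxy does not enter at the same place relative to the existing methoxy in both.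

The compounds shown leave open what a hydroxyl, a fluorine or a dimethylamino group would do at the same aromatic carbon. They also leave open whether the picture holds with chlorine in place of the bromine on the shared core.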